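Fluorine for chlorine on the sulfonamide aryl ring

A few compounds are considered here, and "the series" means these few. Any claim that something is new, unique, unknown or untested is made for them only; others in the source may bear on it.

Compound 1 (`O=S(=O)(Nc1ccc(Cl)cc1Cl)c1ccc(-c2cnc(C3CC3)o2)cc1`) and compound 2 (`O=S(=O)(Nc1ccc(Cl)c(F)c1)c1ccc(-c2cnc(C3CC3)o2)cc1`) share one core and differ only in the aryl group on the sulfonamide nitrogen. In a functional assay on cells (leukaemia cell line, Homo sapiens) for inhibition, read by sulforhodamine B assay, with a stated time of 48 h (on this read-out lower numbers stand for higher toxicity in this test and higher numbers for lower toxicity in this test), compound 1 gives > 100000 nM, which is a limit of the assay rather than a number. In this assay compound 2 likewise gives only a limit, > 100000 nM. The step that the two limits leave unreadable from compound 1 to compound 2 therefore cannot be sized. Compound 3 (`O=S(=O)(Nc1ccc(F)cc1F)c1ccc(-c2cnc(C3CC3)o2)cc1`) differs from compound 2 by 2,4-difluorophenyl in place of 4-chloro-3-fluorophenyl on a sulfonamide nitrogen. Among the measured compounds shown here, the only measured step that bears on this change is a step that the two limits leave unreadable from compound 1 to compound 2, and since (the limit of > 100000 nM in this assay, at which 2 of the 2 values shown sit), it gives no direction to read. The step from compound 2 to compound 3 is therefore expected to be none beyond the scatter, a step that the limit leaves unreadable from compound 2 to compound 3, with the result again most likely a limit. For compound 3 in this assay the estimate is 200000 nM, with a range of 60000 nM to 1000000 nM.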

Compound 3, concentration lethal to 50% of the cells: > 100000 nM
Compound 3: no number, only a limit (the forecaster's own chance of this, stated with the estimate: 80%); the middle value does not contradict the limit.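

No step can be read among compound 1, compound 2 and compound 3 in this assay, as all three give only a limit of the assay and no number: the limit of > 100000 nM in this assay, at which 3 of the 3 values shown sit.

The compounds shown leave open whether changing the aryl group on the sulfonamide nitrogen has any effect on the read-out in this assay.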